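Methoxy in place of ethyl on a carbonyl carbon

This account rests on a few compounds, and the source may have more. Where it says the series, first, only, none or still open, it means among the compounds named here.

In a functional assay on MCF7 cells (Homo sapiens) for inhibition (on this read-out lower numbers stand for stronger inhibition and higher numbers for weaker inhibition), compound 1 `CCCCCCCC[C@@]1(C)SC(=O)C=C1OCC(=O)OCC` gives 10.8 ug/mL and compound 2 `CCCCCCCC[C@@]1(C)SC(=O)C=C1OC(=O)CC` gives 22.6 ug/mL, the higher of the two numbers. Compound 3 `CCCCCCCC[C@@]1(C)SC(=O)C=C1OC(=O)OC` keeps the core of compound 2 but carries methoxy in place of ethyl on a carbonyl carbon. Within the data shown here, only one measured step bears on this, a 2.1-fold higher number from compound 1 to compound 2 (0.32 log units; beyond the scatter), a modest step that exchanged a different pair of groups on an oxygen on an unsaturated carbon. No change beyond the scatter is therefore expected, and the estimated step is a 1.1-fold lower number from compound 2 to compound 3 (0.05 log units; within the scatter). Compound 3 is estimated at 20 ug/mL, with an expected range of 9 ug/mL to 45 ug/mL.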

Compound 3, half-maximal inhibitory concentration: 10.7 ug/mL
Compound 3: the middle estimate sits 1.9-fold (0.27 log units) above what was measured; the range from low to high includes it.
By their numbers in this assay, from the lowest: compounds 3 and 1 (each within the scatter of the next); then compound 2.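

In this assay the ethyl group on a carbonyl carbon proves not to be interchangeable with methoxy, with a 2.1-fold lower number from compound 2 to compound 3 (0.32 log units; beyond the scatter) for that exchange, although each group counts 2 heavy atoms. The comparison with the other ester shows a 1.0-fold lower number from compound 1 to compound 3 (0.00 log units; within the scatter) for methoxycarbonyl in place of (ethoxycarbonyl)methyl on an oxygen on an unsaturated carbon, so these two groups cannot be told apart here. Nothing available accounts for the difference between ethyl and methoxy. On these data alone, whether an amine or a longer chain in place of methoxy on this carbonyl carbon would lower the number further remains open.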